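Chloro to Methoxy Exchange Against a Cytotoxicity Ceiling

The compounds below may be only part of what the source reports. "The series", "measured", "known", "first", "only" and "open" are said of these compounds alone.

Compound 1 `CC1CCN(C2CCN(S(=O)(=O)c3cccc(Cl)c3)CC2)CC1` was examined in an ADME assay on HCT-116 cells (Homo sapiens) for cytotoxicity, read by CellTiter-Glo, with a stated time of 72 h; on this read-out higher numbers stand for weaker inhibition and lower numbers for stronger inhibition. In this assay compound 1 gives > 5000 nM, which is a limit of the assay and not a number. Compound 2 `COc1cccc(S(=O)(=O)N2CCC(N3CCC(C)CC3)CC2)c1` carries methoxy in place of chloro on an aromatic carbon. In this assay compound 2 gives > 5000 nM, again only a limit. The step that the two limits leave unreadable from compound 1 to compound 2 accordingly cannot be sized. Compound 3 `CC1CCN(C2CCN(S(=O)(=O)c3ccccc3-c3ccc(Cl)cc3)CC2)CC1` rests on a different core; how its core differs from that of compound 1 is not broken down here. In this assay compound 3 gives > 5000 nM, likewise a limit. Compound 4 `COc1ccc(-c2ccccc2S(=O)(=O)N2CCC(N3CCC(C)CC3)CC2)cc1` bears methoxy in place of chloro on an aromatic carbon. For the measured compounds named here, this is the same kind of change as the one from compound 1 to compound 2, though the place differs: there the group sits meta to a large group, here para to a large group. Every measured value sits at the limit of > 5000 nM in this assay, at which 3 of the 3 values shown sit, so the change has nowhere produced a readable effect. The step that the limit leaves unreadable from compound 3 to compound 4 is therefore expected to be small. Compound 4 is estimated at 9000 nM, most likely reported once more as a limit rather than a number.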

Compound 4, half-maximal inhibitory concentration: > 5000 nM
Compound 4 was reported as a limit; the forecaster's own chance of this, stated with the estimate: 85%; the middle value is on the limit's open side.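

Compound 3 and compound 4 are both reported only as limits in this assay, so the step between them, like the one between compound 1 and compound 2, cannot be read, and no new step emerges: the limit of > 5000 nM in this assay, at which 4 of the 4 values shown sit.

Whether exchanging chloro for methoxy has any effect in this assay stays open, with no compound shown giving a number.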